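Carboxylic acid in place of methylamide on a shared core

This account rests on a few compounds, and the source may have more. Where it says the series, first, only, none or still open, it means among the compounds named here.

Of the compounds shown here, two from this series have been measured in an assay on CHO cells for displacement of a labelled ligand from adenosine receptor A3 (Homo sapiens); a higher number here means a weaker inhibitor, a lower number a stronger inhibitor. Compound 1, `COc1ccc(CNc2ncc(C(=O)O)c3nc(-c4ccco4)nn23)cc1OC`, carries a carboxylic acid and a benzyl-type amine on the shared core, and in this assay compound 1 gives 159 nM. Compound 2, `CNC(=O)c1cnc(NC(=O)NC2CCCCC2)n2nc(-c3ccco3)nc12`, instead carries a methylamide and a cyclohexyl urea, and in this assay compound 2 gives 18700 nM, the higher of the two numbers and therefore the weaker inhibitor of the pair; the two structures differ in two places, so no single change can be read from them.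

Compound 3, `O=C(Nc1ncc(C(=O)O)c2nc(-c3ccco3)nn12)NC1CCCCC1`, keeps the cyclohexyl urea of compound 2 and changes only the other position: hydroxy in place of methylamino on a carbonyl carbon. Among the compounds with values here, compound 1, the one measured compound that also carries the carboxylic acid, gives 159 nM, which suggests that this change will pull the number downward, although the second difference between compound 1 and compound 2 leaves the size uncertain. The expected step from compound 2 to compound 3 is a 16-fold lower number from compound 2 to compound 3 (1.19 log units; beyond the scatter), a fall beyond the usual scatter. For compound 3 the expected value in this assay is 1200 nM, with a plausible range from 150 nM to 7000 nM.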

Compound 3, inhibition constant: 59400 nM
Compound 3: middle estimate off by 50-fold (1.69 log units), on the low side; measured number outside the range, above it.
By their numbers in this assay, from the lowest: compound 1; then compound 2; then compound 3.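

In this assay, within the data shown here, with the cyclohexyl urea held fixed, putting hydroxy in place of methylamino on a carbonyl carbon gives a 3.2-fold higher number from compound 2 to compound 3 (0.50 log units; beyond the scatter), the first single change that can be read, and it moves the number up, a modest step towards a weaker inhibitor. Compound 3 shares the carboxylic acid with compound 1, yet compound 1 gives 159 nM, while compound 3 gives 59400 nM, so the carboxylic acid alone does not bring a low number, and the group at the other position, the benzyl-type amine or the cyclohexyl urea, counts for a great deal. No accompanying measurement points to a reason for the rise from methylamino to hydroxy.

Going by these compounds, the step is known only with the cyclohexyl urea in place, so it remains open whether the same swap would raise the number on a compound carrying the benzyl-type amine of compound 1. On these data alone, it is also open how other groups on this carbonyl carbon would compare, such as a plain amino group, a methoxy group or a longer ethylamino chain.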